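A fluoromethyl chain in place of a hydroxymethyl chain

The compounds below may be only part of what the source reports. "The series", "measured", "known", "first", "only" and "open" are said of these compounds alone.

Compound 1 `COc1ccc(C(c2ccc(OC)c(OC)c2)[C@H](C)[C@H](C)CO)cc1OC` was tested in a functional assay on HeLa cells (Homo sapiens) for cytotoxicity, read by WST assay, with a stated time of 48 h; on this read-out higher numbers stand for weaker inhibition and lower numbers for stronger inhibition. Compound 1 gives > 100000 nM, which is a limit of the assay rather than a number. Compound 2 `COc1cc(C(c2ccc(O)c(OC)c2)[C@@H](C)[C@@H](C)CO)ccc1O` gives > 100000 nM in this assay, also a limit. Compound 2 thus stands at the limit of > 100000 nM in this assay, at which 2 of the 2 values shown sit, alongside compound 1. Compound 3 `COc1cc(C(c2ccc(O)c(OC)c2)[C@H](CF)C(C)C)ccc1O` has not been measured; it carries 1-(fluoromethyl)-2-methylpropyl in place of 2-(hydroxymethyl)-1-methylpropyl on a saturated chain carbon bound to two aromatic carbons. Within the data shown here, no measured step exists for this change, so in this assay the expected step from compound 2 to compound 3 is a number no higher from compound 2 to compound 3 (the limit leaves the size open), nothing beyond the scatter. Compound 3 is therefore estimated at 100000 nM in this assay, with a range from 30000 nM to 300000 nM.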

Compound 3, half-maximal inhibitory concentration: 19000 nM
Estimate against measurement, compound 3: 5.3-fold (0.72 log units) above; measured number below the stated range.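

In this assay, 1-(fluoromethyl)-2-methylpropyl in place of 2-(hydroxymethyl)-1-methylpropyl gives an at least 5.2-fold lower number from compound 2 to compound 3 (0.72 log units; beyond the scatter). Among these compounds, this is the first sign that the chain on this saturated carbon can shift the read-out, and compound 3 is the first compound here to give a real number. The true size of the step stays unknown because compound 2 has only a limit of the assay: the limit of > 100000 nM in this assay, at which 2 of the 3 values shown sit.

The change swaps the hydroxyl for fluorine and also rearranges the chain, so the compounds shown cannot separate these two differences. Going by these compounds, how an aminomethyl or chloromethyl chain would behave here also remains open.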